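This account rests on a few compounds, and the source may have more. Where it says the series, first, only, none or still open, it means among the compounds named here.

Measured in a functional assay on the whole organism for inhibition, with Rattus norvegicus as the target, with a stated time of 1 h; a higher number here means that more compound is needed for the effect, a lower number that less compound is needed:

Compound 1 `CC1(C)OC(/C=C/c2ccccc2)=CC1=O`: 17 mg/kg
Compound 2 `CC1(C)OC(/C=C/c2ccnc3ccccc23)=CC1=O`: 2.5 mg/kg

Compound 1 has the higher of the two numbers at 17 mg/kg, so more of it is needed for the effect. Compound 2 lies lower at 2.5 mg/kg, a gap beyond the usual scatter. Compound 3 `CC1(C)OC(/C=C/c2ccc(Cl)cc2)=CC1=O`, not yet measured, keeps the core of compound 1 and differs from it in one place: chloro in place of hydrogen on an aromatic carbon. This is chloro in place of hydrogen on an aromatic carbon, para to a large group.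

Among the measured compounds shown here, no two measured compounds differ in only one place, so the data give no direct guide to this change. For the measured compounds named here, the gap between compound 1 and compound 2 shows only that values around this core can lie well apart. With compound 1 at 17 mg/kg as the starting point, a modest step towards a lower number is expected in this assay, probably none beyond the scatter. The expected change is a 1.4-fold lower number from compound 1 to compound 3 (0.15 log units; within the scatter). For compound 3 the estimated value is 12 mg/kg, with an expected range from 4 mg/kg to 35 mg/kg.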

Compound 3, dose for half-maximal effect: 10.3 mg/kg
For compound 3 the middle estimate is 1.2-fold (0.07 log units) above the measured one; low and high end bracket the measured number.
By their numbers in this assay, from the lowest: compound 2; then compounds 3 and 1 (each within the scatter of the next).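

In this assay, among the compounds shown here, the change of chloro in place of hydrogen on an aromatic carbon, para to a large group, gives a 1.7-fold lower number from compound 1 to compound 3 (0.22 log units; within the scatter) and provides the first direct reading of a single change on the shared core. The earlier pair differed in more than one place, whereas this step isolates one position on the six-membered aromatic ring of carbon only and shows that a chlorine atom can enter there without moving the number beyond the usual scatter, so this single change leaves the dose needed for the effect practically unresolved from that of the unsubstituted parent. No supporting data are available to explain this outcome.

For the compounds shown here, the single step leaves open whether this tolerance extends to other groups at the same place, such as fluoro, methoxy, an amine or a carboxylic acid, which could give a step beyond the scatter or none at all. It also leaves open whether chloro would give a similar result at another carbon of the same ring or on a different aromatic group attached to the shared core.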